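The source may hold more compounds than are shown below. What is called first, only, known or untested is meant among the compounds shown, and "the series" means these compounds.

Measured so far, in a functional assay on DU-145 cells (Homo sapiens) for inhibition, read by trypan blue exclusion, with a stated time of 96 h; a lower number here means a stronger inhibitor of growth, a higher number a weaker inhibitor of growth:
Compound 1 `COc1ccccc1/C=C(/SCc1ccc(Cl)c(Cl)c1)C(=O)c1ccc(Cl)cc1`: 10000 nM
Compound 2 `O=C(O)c1ccc(C(=O)/C(=C\c2ccc(O)c([N+](=O)[O-])c2)SCc2ccc(Br)cc2)cc1`: 50000 nM
Compound 3 `Cc1ccsc1/C=C(/SCc1ccc(Cl)c(Cl)c1)C(=O)c1ccc(Cl)cc1`: 50000 nM

Compound 1 has the lowest of these three numbers, and compound 2 and compound 3 both stand clearly higher. Compound 4 `COc1ccccc1/C=C(/SCc1ccc(Cl)cc1)C(=O)c1ccc(Cl)cc1` has not yet been measured. It departs from compound 1 by hydrogen in place of chloro on an aromatic carbon, which turns 3,4-dichlorobenzyl into 4-chlorobenzyl. Within the data shown here, no measured step touches this chlorine. The only one available, a 5.0-fold higher number from compound 1 to compound 3 (0.70 log units; beyond the scatter), changes a different part of the molecule and gives only a rough sense of size. A smaller change is therefore expected in this assay, leaning slightly towards a higher number. The estimated step is a 1.5-fold higher number from compound 1 to compound 4 (0.18 log units; within the scatter). For compound 4 the expected value is 15000 nM, with an estimated range of 5000 nM to 50000 nM.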

Compound 4, concentration for 50% growth inhibition: 1000 nM
Compound 4: the middle estimate sits 15-fold (1.18 log units) above what was measured; measured number outside the range, below it.
By their numbers in this assay, from the lowest: compound 4; then compound 1; then compounds 2 and 3 (each within the scatter of the next).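

In this assay, the change from 3,4-dichlorobenzyl to 4-chlorobenzyl gives a 10-fold lower number from compound 1 to compound 4 (1.00 log units; beyond the scatter). Among these compounds, this is the first measured step at this side of the molecule, and it shows that the chloro group that leaves is not needed for growth inhibition with the rest of compound 1 in place. No evidence is at hand to explain the drop in the number.

As far as these compounds go, whether fluoro or an amine at this same aromatic carbon would match hydrogen stays open. So does whether the step would hold alongside 3-methylthiophen-2-yl in place of 2-methoxyphenyl.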